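Shared-core anilines: acid replaced by cyclopropyl amide

This account rests on a few compounds, and the source may have more. Where it says the series, first, only, none or still open, it means among the compounds named here.

Compound 2 `O=C(O)CSc1ccc(NCc2cccc(Oc3ccccc3)c2)cc1` gives 324 nM in a functional assay on CHO cells for agonist activity at Free fatty acid receptor 1 (Homo sapiens) (a higher number here means that more compound is needed for the effect, a lower number that less compound is needed), the highest of the two numbers available; the nearest is compound 3 `Cc1nc(-c2ccc(C(F)(F)F)cc2)sc1CNc1ccc(C(C)CC(=O)O)cc1` with 58.9 nM, a gap beyond the scatter. Compound 1 `Cc1nc(-c2ccc(C(F)(F)F)cc2)sc1CNc1ccc(CC(=O)O)cc1` returns only a limit, < 10000 nM, not a number. Among the compounds with values here, the one measured step, a step that the limit leaves unreadable from compound 1 to compound 3, therefore cannot be read for size because of the limit of < 10000 nM in this assay, at which 1 of the 3 values shown sits.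

Compound 4 `CC(C)NC(=O)[C@H]1C[C@@H]1c1ccc(NCc2cccc(Oc3ccccc3)c2)cc1` is compound 2 with 2-(isopropylcarbamoyl)cyclopropyl in place of (carboxymethyl)sulfanyl on an aromatic carbon. Within the data shown here, none of the measured steps bears on this change: the only step recorded alters a carboxymethyl chain on the core, whereas here the whole (carboxymethyl)sulfanyl group departs and a 2-(isopropylcarbamoyl)cyclopropyl group enters, and the core of compound 2 differs from that of compounds 1 and 3. No comparison in the set tells how this assay responds to exchange of a carboxylic acid for a neutral amide, so the expectation rests on the starting value alone and carries a wide range. Compound 4 is estimated at 1200 nM in this assay, within 150 nM to 9000 nM. The expected step of a 3.7-fold higher number from compound 2 to compound 4 (0.57 log units; beyond the scatter) is thus a loss, but one stated with low confidence.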

Compound 4, half-maximal effective concentration: 12.6 nM
Compound 4: the middle estimate sits 95-fold (1.98 log units) above what was measured; the whole stated range lies above it.
By their numbers in this assay, from the lowest: compound 4; then compound 3; then compound 2.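

Within the data shown here, exchanging (carboxymethyl)sulfanyl for 2-(isopropylcarbamoyl)cyclopropyl on the aromatic carbon para to a large group gives a 26-fold lower number from compound 2 to compound 4 (1.41 log units; beyond the scatter) in this assay, and this is the first step whose size can be read. On the core of compound 2, therefore, a carboxylic acid at this position is not needed for a low number: the entering group carries an amide and no carboxylic acid, and compound 4 gives 12.6 nM. The change alters the linking atoms, the ring, the end group and the defined stereocentres in a single step, so the size of the step cannot be divided among them, and nothing measured here points to a cause for it.

Open, as far as these compounds go, is which part of the entering group carries the step: a carboxylic acid on the same cyclopropyl group, a primary amide in place of the isopropyl amide, or the opposite stereoisomer could each separate these parts. Also open, from the compounds shown here alone, is whether the same 2-(isopropylcarbamoyl)cyclopropyl group behaves alike on the core of compound 3.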